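This account rests on a few compounds, and the source may have more. Where it says the series, first, only, none or still open, it means among the compounds named here.

Measured so far in a functional assay on HL-60 cells (Homo sapiens) for activation; a higher number here means that more compound is needed for the effect, a lower number that less compound is needed:
compound 1 `CCCCCCCCCCCCNCC(N)CCCN` gives 1000 nM
compound 2 `CCCCCCCCCCCCNC(=O)[C@@H](N)CCC(N)=O` gives 7940 nM
compound 3 `CCCCCCCCCCCCNC(=O)C(N)CCCN` gives 2510 nM

Compound 1 stands lowest of the three numbers in this assay; compound 3 is nearest, compound 2 furthest, both beyond the scatter. Among the measured compounds shown here, the only measured step, a 3.2-fold lower number from compound 2 to compound 3 (0.50 log units; beyond the scatter), concerns the group on a carbonyl carbon and not the place changed here. Compound 4 `CCCCCCCCCCCCNCCN=C(N)N` differs from compound 1 by a group of 5 heavy atoms (2 carbon, 3 nitrogen; no ring) in place of a group of 6 heavy atoms (4 carbon, 2 nitrogen; no ring), on a saturated chain carbon bound to an amine nitrogen. For the measured compounds named here, no measured step bears directly on this change, so the expectation rests on the size of the one side-chain step seen and is held wide. A modest rise in the number is expected, as a 1.6-fold higher number from compound 1 to compound 4 (0.20 log units; within the scatter). For compound 4 in this assay the estimate is 1600 nM, range 400 nM to 6300 nM.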

Compound 4, half-maximal effective concentration: 1000 nM
Beside the measured number, compound 4's estimate is 1.6-fold (0.20 log units) above it, and the stated range covers the measured number.
By their numbers in this assay, from the lowest: compounds 1 and 4 (each within the scatter of the next); then compound 3; then compound 2.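

In this assay the change on a saturated chain carbon bound to an amine nitrogen gives no change at the digits printed from compound 1 to compound 4 (within the scatter) and so leaves the number in place. At this position, the 1,4-diaminobutyl group of compound 1 can thus give way to a smaller group with one double bond and one fewer hydrogen-bond acceptor, with no shift beyond the scatter. No measured evidence accounts for this result.

On these data alone, whether a carboxylic acid or a hydroxyl group at this place would hold the number remains open. So does the effect of a shorter chain on the amine nitrogen of compound 4.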